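A few compounds are considered here, and "the series" means these few. Any claim that something is new, unique, unknown or untested is made for them only; others in the source may bear on it.

Measured compounds:
compound 1 `CCCn1cnc2c(N)nc(NCCCc3ccccc3)nc21` — in an assay on CHO cells for displacement of a labelled ligand from adenosine receptor A1 (Homo sapiens) (a lower number here means a stronger inhibitor, a higher number a weaker inhibitor), compound 1 gives 3640 nM
compound 2 `CCCn1cnc2c(NCCCc3ccccc3)ncnc21` — in this assay compound 2 gives 18600 nM
compound 3 `CCCn1c(Br)nc2c(NCc3ccccc3)ncnc21` — in this assay compound 3 gives 5620 nM

Of the three numbers, compound 2 has the highest, and both gaps lie beyond the scatter: compound 3 gives a lower number, compound 1 a still lower one. Compound 2 is thus the weakest inhibitor among the three.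

Compound 4 `CCCn1c(-c2ccco2)nc2c(NCCCc3ccccc3)ncnc21` has not been measured. It differs from compound 2 in one place: furan-2-yl in place of hydrogen on an aromatic carbon. Among the measured compounds shown here, no pair of measured compounds shows this particular change, so the size of the step cannot be read from the data. Compound 3 carries a bromine at the same position, but its amine side chain also differs from that of compound 2, so those two values alone cannot isolate the effect. The account therefore rests on an expectation: a moderate drop in the number, beyond the scatter, is expected for the step from compound 2 to compound 4, given as a 3.1-fold lower number from compound 2 to compound 4 (0.49 log units; beyond the scatter). For compound 4 in this assay the estimated value is 6000 nM, with a range from 1500 nM to 25000 nM.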

Compound 4, inhibition constant: 378 nM
Compound 4: the middle estimate sits 16-fold (1.20 log units) above what was measured; the measured number lies below the stated range.
By their numbers in this assay, from the lowest: compound 4; then compounds 1 and 3 (each within the scatter of the next); then compound 2.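

In this assay, among the compounds shown here, furan-2-yl in place of hydrogen on the aromatic carbon next to the ring atom that bears a propyl group gives a 49-fold lower number from compound 2 to compound 4 (1.69 log units; beyond the scatter), and this is the first step that isolates a change at this position. It shows that this carbon can carry a five-membered aromatic ring with 1 hetero atom and that such a change can move the number by a large step. Nothing available here accounts for the size of this step.

The compounds shown leave open whether a phenyl, a thiophen-2-yl or a plain methyl on this carbon would give a step of similar size. They also leave open whether furan-2-yl would give such a step with the amine side chain of compound 3.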